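The source may hold more compounds than are shown below. What is called first, only, known or untested is meant among the compounds shown, and "the series" means these compounds.

Working notes on the series. Compound 1 `N#Cc1ccc(Cc2cnc(CCc3ccc(-c4ccccc4C(=O)O)cc3)[nH]2)cc1` is the weaker of the two compounds measured in an in vitro functional assay on cells for agonist activity at Bombesin receptor subtype-3 (Homo sapiens), read by luminescence and calcium flux; a lower number here means that less compound is needed, a higher number that more compound is needed for the effect: compound 1 gives 5890 nM, while compound 2 `CCCCc1cnc(C(CCC)Cc2ccc(-c3ccccc3C(=O)O)cc2)[nH]1` gives 1180 nM, a gap beyond the scatter. The next compound, compound 3 `CCC(C)(CC)Cc1cnc(CCc2ccc(-c3ccccc3C(=O)O)cc2)[nH]1`, differs from compound 1 by 1-ethyl-1-methylpropyl in place of 4-cyanophenyl on a saturated chain carbon bound to an aromatic carbon. Within the data shown here, no measured pair shows this change directly; the only guide is that compound 2, carrying saturated chains rather than an aromatic group, sits lower. The step of a 2.7-fold lower number from compound 1 to compound 3 (0.43 log units; beyond the scatter) is therefore expected to go downward, beyond the scatter but modestly. Compound 3 is estimated at 2200 nM, within 700 nM to 6500 nM.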

Compound 3, half-maximal effective concentration: 76 nM
For compound 3 the middle estimate is 29-fold (1.46 log units) above the measured one; measured number outside the range, below it.
By their numbers in this assay, from the lowest: compound 3; then compound 2; then compound 1.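

In this assay, the saturated chain carbon bound to an aromatic carbon proves a highly sensitive place: 1-ethyl-1-methylpropyl in place of 4-cyanophenyl gives a 78-fold lower number from compound 1 to compound 3 (1.89 log units; beyond the scatter) and shows that an aromatic ring is not required on this carbon for a low number. Nothing on hand explains the size of this step. The change removes the nitrile and the benzene ring together, so their separate contributions remain unresolved. A plain phenyl or a straight hexyl chain at this place would help separate them.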